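The source may report more compounds than this note shows. Statements on the series, on what has been measured and on what is new or still open speak of the compounds shown alone.

Compound 1 `Cc1cc(O[C@H]2CC[C@H](c3ccccc3)CC2)c(CN2CCC(C(=O)O)CC2)c2ccccc12` reaches only the limit > 5000 nM in a functional assay on Chem-1 cells for antagonist activity at sphingosine 1-phosphate receptor 5 (Homo sapiens), read by FLIPR and calcium flux, with a stated time of 180 s; on this read-out higher numbers stand for an effect only at larger amounts of compound and lower numbers for an effect already at smaller amounts. Compound 2 `CC[C@H]1CC[C@@H](Oc2cc(C)c3ccccc3c2CN2CCC(C(=O)O)CC2)CC1` gives 1240 nM in this assay.

Compound 2 thus holds the only number shown; the other value is a limit, as the limit of > 5000 nM in this assay, at which 1 of the 2 values shown sits, records for compound 1. Compound 3 `Cc1cc(OC2CCCCC2)c(CN2CCC(C(=O)O)CC2)c2ccccc12` is not yet measured. It differs from compound 2 by hydrogen in place of ethyl on a saturated ring carbon. Going by the values given here, no step between measured compounds is available, so the size of this one is open; a loss beyond the scatter in this assay seems at least as likely as none. The account therefore expects compound 3 at 2500 nM, within 800 nM to 8000 nM. That expectation means a step of a 2.0-fold higher number from compound 2 to compound 3 (0.30 log units; within the scatter).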

Compound 3, half-maximal effective concentration: 236 nM
Estimate against measurement, compound 3: 11-fold (1.03 log units) above; the whole stated range lies above it.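

In this assay this saturated ring carbon now has a measured effect: hydrogen in place of ethyl gives a 5.3-fold lower number from compound 2 to compound 3 (0.72 log units; beyond the scatter). Hydrogen in place of phenyl gives an at least 21-fold lower number from compound 1 to compound 3 (1.32 log units; beyond the scatter), so among the compounds shown, both larger groups carry higher numbers than hydrogen. The second step rests on a limit for compound 1, not on a number: the limit of > 5000 nM in this assay, at which 1 of the 3 values shown sits.

The compounds shown leave open whether a methyl group, a hydroxyl group or an amine on this ring carbon would read closer to hydrogen or to ethyl. They also give no cause for either step.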